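A Nitrile in Place of Chlorine: Expecting Compound 4

The source may report more compounds than this note shows. Statements on the series, on what has been measured and on what is new or still open speak of the compounds shown alone.

Measured compounds:
compound 1 `C=CC(=O)N1C(=O)CC(c2ccc(Cl)cc2)Sc2ccccc21` — 82400 nM
compound 2 `C=CC(=O)N1C(=O)CC(c2ccccc2)Sc2ccccc21` — 85900 nM
compound 3 `C=CC(=O)N1C(=O)CC(c2ccc(C(=O)OC)cc2)Sc2ccccc21` — 79600 nM

The three compounds share one core and differ only in the group carried on the pendant phenyl ring. In a functional assay on MOLT-4 cells (Homo sapiens) for cytotoxicity, read by CCK-8 assay, with a stated time of 24 h (a higher number here means a weaker inhibitor, a lower number a stronger inhibitor), compound 1 gives 82400 nM. Its number lies within the scatter of both others, so compound 1 stands neither apart from nor distinct among the three: the step of a 1.0-fold higher number from compound 1 to compound 2 (0.02 log units; within the scatter) and the step of a 1.0-fold lower number from compound 1 to compound 3 (0.02 log units; within the scatter) are both too small to count, as is a 1.1-fold lower number from compound 2 to compound 3 (0.03 log units; within the scatter).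

Compound 4 `C=CC(=O)N1C(=O)CC(c2ccc(C#N)cc2)Sc2ccccc21` is the next member of the set. It differs from compound 1 in one place: cyano in place of chloro on an aromatic carbon. Among the measured compounds shown here, the steps that bear on this change are exactly the three above, each of which exchanged a group on the same aromatic carbon and each of which left the number in this assay where it was. Nothing in these data suggests that a nitrile at that carbon would behave differently from chloro, hydrogen or methoxycarbonyl, so for compound 4 a step of about a 1.0-fold lower number from compound 1 to compound 4 (0.00 log units; within the scatter) is expected, that is, none beyond the scatter. Compound 4 is therefore estimated at 82000 nM in this assay, with a plausible range from 45000 nM to 150000 nM.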

Compound 4, half-maximal inhibitory concentration: 88700 nM
Beside the measured number, compound 4's estimate is 1.1-fold (0.03 log units) below it; the range from low to high includes it.
By their numbers in this assay, from the lowest: compounds 3, 1, 2 and 4 (each within the scatter of the next).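

With the nitrile in place, this assay shows a 1.1-fold higher number from compound 1 to compound 4 (0.03 log units; within the scatter) and a 1.1-fold higher number from compound 3 to compound 4 (0.05 log units; within the scatter) as well as a 1.0-fold higher number from compound 2 to compound 4 (0.01 log units; within the scatter) in this series. Cyano, which brings a triple bond that none of the earlier groups carried, therefore joins chloro, hydrogen and methoxycarbonyl on this aromatic carbon, para to a large group, and all four compounds now lie within the scatter of one another, so the 4-chlorophenyl to 4-cyanophenyl change gives no measurable separation here. No measurement is available that explains why the number holds across these groups.

No step among these compounds lies beyond the scatter. From the compounds shown here alone, they do not reveal what, if anything, at this carbon would move the number, and whether an amine, a carboxylic acid or a longer chain would do so remains open. Also open, going by these compounds, is whether the same flatness would hold for a group at another carbon of the pendant ring or for a change to the shared core.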